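The compounds below may be only part of what the source reports. "The series", "measured", "known", "first", "only" and "open" are said of these compounds alone.

Compound 3 `S=c1oc(-c2ccc3c(c2)OCCO3)nn1CN1CCN(c2ccccc2)CC1` carries an unsubstituted phenyl on the amine nitrogen in a ring. In a functional assay on HeLa cells (Homo sapiens) for antiproliferative activity, read by MTT assay, with a stated time of 48 h (a lower number here means a stronger inhibitor, a higher number a weaker inhibitor), compound 3 gives > 50000 nM, which is a limit of the assay rather than a number. Compound 1 `Fc1ccccc1N1CCN(Cn2nc(-c3ccc4c(c3)OCCO4)oc2=S)CC1` gives 37300 nM in this assay. Compound 2 `S=c1oc(-c2ccc3c(c2)OCCO3)nn1CN1CCN(c2ccc(Cl)cc2)CC1` gives > 50000 nM, again a limit. The change from compound 3 to compound 4 `COc1ccccc1N1CCN(Cn2nc(-c3ccc4c(c3)OCCO4)oc2=S)CC1` is methoxy in place of hydrogen on an aromatic carbon. The measured step that bears most closely on it is an at least 1.3-fold higher number from compound 1 to compound 3 (0.12 log units; that floor lies within the scatter), a change on the same phenyl; an at least 1.3-fold higher number from compound 1 to compound 2 (0.12 log units; that floor lies within the scatter) and a step that the two limits leave unreadable from compound 2 to compound 3 tell little, as the limit of > 50000 nM in this assay, at which 2 of the 3 values shown sit, leaves their size unreadable. Compound 4 is expected to give 35000 nM, within 15000 nM to 80000 nM, a step of an at least 1.4-fold lower number from compound 3 to compound 4 (0.15 log units; that floor lies within the scatter). This expectation rests on compound 1 returning 37300 nM with a substituent on that phenyl.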

Compound 4, half-maximal inhibitory concentration: > 50000 nM
Compound 4: a limit, no number; the forecaster's own chance of this, stated with the estimate: 40%; at least 1.4-fold (0.15 log units) between middle value and limit.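

In this assay a methoxy ortho to a large group leaves compound 4 at a limit of the assay, so a substituent on that carbon does not by itself yield a number. Going by these compounds alone, the steps from compound 4 to compound 2 and compound 3 cannot be read, and against compound 1, the only compound with a number, methoxy in place of fluoro gives an at least 1.3-fold higher number from compound 1 to compound 4 (0.12 log units; that floor lies within the scatter). The compounds now gather at one limit: the limit of > 50000 nM in this assay, at which 3 of the 4 values shown sit.

On these data alone, whether an amine, a hydroxy or a longer chain in that place would give a number stays open.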